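Heteroaryl swap on the sulfonamide nitrogen of a terpenoid sulfonamide

A few compounds are considered here, and "the series" means these few. Any claim that something is new, unique, unknown or untested is made for them only; others in the source may bear on it.

Measured so far:
Compound 1 `C=C1CC[C@@H]2[C@](C)(COC(C)=O)[C@H](OC(C)=O)CC[C@@]2(C)[C@H]1CC(Nc1ccc(S(=O)(=O)Nc2nccs2)cc1)C1=CCOC1=O`: 41800 nM
Compound 2 `C=C1CC[C@@H]2[C@](C)(COC(C)=O)[C@H](OC(C)=O)CC[C@@]2(C)[C@H]1CC(Nc1ccc(S(=O)(=O)Nc2ncccn2)cc1)C1=CCOC1=O`: 5850 nM

In a functional assay on UO-31 cells (Homo sapiens) for inhibition, read by sulforhodamine B assay, with a stated time of 48 h (on this read-out higher numbers stand for lower toxicity in this test and lower numbers for higher toxicity in this test), compound 2 holds the lowest of the two numbers; compound 1 sits a 7.1-fold lower number from compound 1 to compound 2 (0.85 log units; beyond the scatter) away. Compound 3 `C=C1CC[C@@H]2[C@](C)(COC(C)=O)[C@H](OC(C)=O)CC[C@@]2(C)[C@H]1CC(Nc1ccc(S(=O)(=O)Nc2cc(C)on2)cc1)C1=CCOC1=O` carries 5-methyl-1,2-oxazol-3-yl in place of pyrimidin-2-yl on a sulfonamide nitrogen. For the measured compounds named here, only that one step concerns the group on the sulfonamide nitrogen, and it was beyond the scatter, so this position matters, but nothing measured tells how a five-membered 1,2-oxazole behaves. Compound 3 is therefore expected to land near compound 2 or somewhat higher, an estimated 2.1-fold higher number from compound 2 to compound 3 (0.31 log units; beyond the scatter), at 12000 nM within 3000 nM to 50000 nM.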

Compound 3, concentration lethal to 50% of the cells: 7330 nM
For compound 3 the middle estimate is 1.6-fold (0.21 log units) above the measured one, within the range that was stated.
By their numbers in this assay, from the lowest: compounds 2 and 3 (each within the scatter of the next); then compound 1.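

The step of a 1.3-fold higher number from compound 2 to compound 3 (0.10 log units; within the scatter) in this assay shows that the six-membered pyrimidin-2-yl ring on the sulfonamide nitrogen can give way to the five-membered 5-methyl-1,2-oxazol-3-yl ring without a change beyond the scatter. The step of a 5.7-fold lower number from compound 1 to compound 3 (0.76 log units; beyond the scatter) then sets 1,3-thiazol-2-yl apart from both other groups, so the earlier gap is not peculiar to pyrimidin-2-yl. No evidence at hand explains this difference. Open, on these data alone, is whether the methyl on the 1,2-oxazole contributes anything, and how a pyridin-2-yl or plain phenyl group on this nitrogen would read.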